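Thiosemicarbazones on the terpene core: hydroxyphenyl to pyrrolyl

The source may report more compounds than this note shows. Statements on the series, on what has been measured and on what is new or still open speak of the compounds shown alone.

Measured compounds:
compound 1 `CC1=CC[C@H](C(C)(C)N=C=S)CC1` — > 100000 nM (a limit)
compound 2 `CC1=CC[C@H](C(C)(C)NC(=S)N/N=C/c2ccccc2O)CC1` — 17500 nM
compound 3 `CC1=CC[C@H](C(C)(C)NC(=S)N/N=C/c2ccccc2[N+](=O)[O-])CC1` — 94700 nM
compound 4 `CC1=CC[C@H](C(C)(C)NC(=S)N/N=C/c2ccc[nH]2)CC1` — not yet measured

In a functional assay on MCF7 cells (Homo sapiens) for inhibition, read by sulforhodamine B assay, with a stated time of 48 h (a lower number here means a stronger inhibitor of growth, a higher number a weaker inhibitor of growth), compound 1 gives only a limit, > 100000 nM. Among the numbers shown, compound 2 stands lowest with 17500 nM in this assay; its nearest neighbour is compound 3 at 94700 nM, a gap of a 5.4-fold higher number from compound 2 to compound 3 (0.73 log units; beyond the scatter). For the measured compounds named here, that single step is the only measured change at the aromatic ring and it says that swapping the substituent there can move the result by a modest but real amount. The change now followed is 1H-pyrrol-2-yl in place of 2-hydroxyphenyl on a carbon with a double bond to nitrogen. Here the whole ring is exchanged rather than a substituent, and the hydrogen-bond acceptor is lost while a donor remains, so there is nothing that tells whether the number will rise or fall; a modest shift in either direction, or none beyond the scatter, is plausible. Compound 4 is therefore expected near 30000 nM, within 10000 nM to 90000 nM. This estimate implies a step of a 1.7-fold higher number from compound 2 to compound 4 (0.23 log units; within the scatter), expected to stay close to the scatter.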

Compound 4, concentration for total growth inhibition: 11500 nM
Estimate against measurement, compound 4: 2.6-fold (0.42 log units) above; low and high end bracket the measured number.
By their numbers in this assay, from the lowest: compounds 4 and 2 (each within the scatter of the next); then compound 3. At a limit, above all of these: compound 1.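

In this assay, exchanging the whole ring gives a 1.5-fold lower number from compound 2 to compound 4 (0.18 log units; within the scatter), so the 2-hydroxyphenyl group on the carbon with a double bond to nitrogen is not required for a value in this range: 1H-pyrrol-2-yl, with fewer heavy atoms and no hydrogen-bond acceptor, reads the same within the scatter. For the compounds shown here, the earlier step, a 5.4-fold higher number from compound 2 to compound 3 (0.73 log units; beyond the scatter), showed only that a substituent change on the aromatic ring can shift the number; this step shows that a five-membered aromatic ring with a hetero atom is tolerated at this place. No measurement shown bears on why the two rings read alike.

As far as these compounds go, compound 2 and compound 4 both carry a hydrogen-bond donor on the ring, so whether one is needed remains open. An unsubstituted phenyl or a furan-2-yl group would address that question.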